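The source may report more compounds than this note shows. Statements on the series, on what has been measured and on what is new or still open speak of the compounds shown alone.

Compounds that share one core spread widely in a physicochemical assay for solubility, in phosphate buffer, at pH 7.4; a higher number here means a more soluble compound, a lower number a less soluble compound. Compound 1 `CN(C)C1CCN(c2nccnc2OC2CN(c3ccc4ccccc4n3)C2)CC1`, which carries 4-(dimethylamino)piperidin-1-yl, gives 500000 nM. Compound 2 `N#CC1CCN(c2nccnc2OC2CN(c3ccc4ccccc4n3)C2)CC1`, which carries 4-cyanopiperidin-1-yl, gives 66000 nM, and the cyano group in place of dimethylamino amounts to a 7.6-fold lower number from compound 1 to compound 2 (0.88 log units; beyond the scatter). Compound 3 `Cc1ccc(-c2nccnc2OC2CN(c3ccc4ccccc4n3)C2)cc1`, which carries 4-methylphenyl, gives < 1000 nM, and this is a limit of the assay, not a number. Compound 3 stands lowest of the three, and all that is known of it is the limit of < 1000 nM in this assay, at which 1 of the 3 values shown sits.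

Compound 4 `c1ccc2nc(N3CC(Oc4nccnc4-c4cccc5ncccc45)C3)ccc2c1` has quinolin-5-yl in place of 4-methylphenyl on an aromatic carbon. For the measured compounds named here, the steps that bear on this change are the two that put 4-methylphenyl at that same place, an at least 500-fold lower number from compound 1 to compound 3 (2.69 log units; beyond the scatter) and an at least 66-fold lower number from compound 2 to compound 3 (1.81 log units; beyond the scatter), and both are large. Each of them replaced a piperidine group with an aromatic one. Going by the values given here, compound 4 only swaps one aromatic group for another, and no measured pair shows such a swap. A large step is therefore not expected, only a small rise, or possibly nothing beyond the scatter. The estimate amounts to an expected at least 1.5-fold higher number from compound 3 to compound 4 (0.17 log units; that floor lies within the scatter). Compound 4 is expected at 1500 nM, within an estimated range from 300 nM to 8000 nM.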

Compound 4, solubility: 47000 nM
Compound 4: the middle estimate sits 31-fold (1.50 log units) below what was measured, outside the stated range (above it).
By their numbers in this assay, from the lowest: compounds 4 and 2 (each within the scatter of the next); then compound 1. At a limit, below all of these: compound 3.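

Swapping one aromatic group for another at this place on the shared core is not a neutral change in this assay: quinolin-5-yl in place of 4-methylphenyl gives an at least 47-fold higher number from compound 3 to compound 4 (1.67 log units; beyond the scatter). An aromatic group here therefore need not mean a large drop from the piperidine compounds, as compound 3 alone had suggested: there is a 1.4-fold lower number from compound 2 to compound 4 (0.15 log units; within the scatter), so quinolin-5-yl and 4-cyanopiperidin-1-yl cannot be told apart, while the gap to the dimethylamino compound remains, with an 11-fold lower number from compound 1 to compound 4 (1.03 log units; beyond the scatter). Compound 3 is known only by a limit, so the step up from it gives a floor and not a true size: the limit of < 1000 nM in this assay, at which 1 of the 4 values shown sits.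

From the compounds shown here alone, what remains open is which part of quinolin-5-yl matters, since it differs from 4-methylphenyl both in its ring nitrogen and in its second ring, and these two compounds cannot separate the two features. Nor do the compounds shown tell whether a phenyl group carrying an amine or a carboxylic acid at this place would stand nearer to compound 1 or to compound 3.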